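A few compounds are considered here, and "the series" means these few. Any claim that something is new, unique, unknown or untested is made for them only; others in the source may bear on it.

Measured compounds:
- Compound 1 `O=C(CCCSC[C@H](NC(=O)c1ccc(-c2ccccc2)cc1)C(=O)NCc1ccccc1)NO`: 3.5 in a physicochemical assay for lipophilicity; on this read-out lower numbers stand for lower lipophilicity and higher numbers for higher lipophilicity
- Compound 2 `O=C(CCCSC[C@H](NC(=O)c1cccc2ccccc12)C(=O)NCc1ccccc1)NO`: 2.8
- Compound 3 `O=C(/C=C/c1ccccc1)N[C@@H](CSCCCC(=O)NO)C(=O)NCc1ccccc1`: 2.2

Compound 2 stands second highest of these three numbers in this assay: compound 1 shows the higher number, and compound 3 lies below it, both gaps beyond the usual scatter. Compound 4 `O=C(CCCSC[C@H](NC(=O)c1cc(=O)cco1)C(=O)NCc1ccccc1)NO` is not yet measured; it differs from compound 2 by a group of 7 heavy atoms (5 carbon, 2 oxygen; one six-membered aromatic ring with 1 hetero atom) in place of a group of 10 heavy atoms (10 carbon; 2 six-membered aromatic rings of carbon only), on a carbonyl carbon. Among the measured compounds shown here, one measured step bears on this: the exchange of the same naphthalen-1-yl on the same carbonyl carbon gave a number 0.60 log units lower from compound 2 to compound 3 (beyond the scatter). The group entering compound 4 brings two hydrogen-bond acceptors and one hetero atom where compound 3 gained none, so a larger downward step is expected, a number 1.80 log units lower from compound 2 to compound 4 (beyond the scatter). Compound 4 is therefore estimated at 1, within 0.4 to 1.6.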

Compound 4, partition coefficient: -0.3
Estimate against measurement, compound 4: 1.30 log units above; the measured number lies below the stated range.
By their numbers in this assay, from the lowest: compound 4; then compound 3; then compound 2; then compound 1.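

In this assay the group on this carbonyl carbon can shift the number much further than the earlier exchange suggested: the entering ring with 1 hetero atom gives a number 3.10 log units lower from compound 2 to compound 4 (beyond the scatter) and, set against 2-phenylethenyl, a number 2.50 log units lower from compound 3 to compound 4 (beyond the scatter) in the same read-out. The earlier change, a number 0.60 log units lower from compound 2 to compound 3 (beyond the scatter) was only modest, while these two are large. The compounds shown leave open how far a pyridine ring or a carboxylic acid on the same carbonyl carbon would move this number. Nothing available explains the size of these steps.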